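The source may report more compounds than this note shows. Statements on the series, on what has been measured and on what is new or still open speak of the compounds shown alone.

Of the compounds shown here, three of one series have been measured in an assay on HEK293 cells for displacement of a labelled ligand from Neuronal acetylcholine receptor; alpha3/beta4 (Homo sapiens), read by scintillation counting; a higher number here means a weaker inhibitor, a lower number a stronger inhibitor. Compound 1 `COc1ccncc1OC[C@@H]1CCCN1` gives 2900 nM, compound 2 `Oc1cccc(OC[C@@H]2CCCN2)c1` gives 3800 nM, and compound 3 `COc1ncccc1OC[C@@H]1CCCN1` gives 5300 nM. Compound 3 thus carries the largest of the three numbers, but its gaps to compound 2 and to compound 1 both fall within the usual scatter, so the three cannot be separated in this assay. Compound 4 `COc1ncccc1OC[C@@H]1CCCN1C` differs from compound 3 by methyl in place of hydrogen on an amine nitrogen in a ring. Within the data shown here, no measured pair shows this change, so there is nothing to anchor its size; a step from compound 3 to compound 4 of a 1.2-fold higher number from compound 3 to compound 4 (0.09 log units; within the scatter) is expected, which stays within the scatter. Compound 4 is estimated at 6500 nM, with a range from 2500 nM to 18000 nM.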

Compound 4, inhibition constant: 793 nM
Compound 4: middle estimate off by 8.2-fold (0.91 log units), on the high side, outside the stated range (below it).
By their numbers in this assay, from the lowest: compound 4; then compounds 1, 2 and 3 (each within the scatter of the next).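

Methyl in place of hydrogen on an amine nitrogen in a ring gives the first step in the series that lies beyond the scatter: in this assay the change produces a 6.7-fold lower number from compound 3 to compound 4 (0.83 log units; beyond the scatter). The amine nitrogen is therefore a position where one added carbon moves the number clearly, in the direction of a stronger inhibitor.

On these data alone, whether ethyl or a longer chain on this nitrogen continues the step remains open, as does whether methyl there acts alike on the core of compound 1. Nothing at hand gives a reason for the step.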